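Swapping one methyl for hydrogen on a lone measured compound

The source may report more compounds than this note shows. Statements on the series, on what has been measured and on what is new or still open speak of the compounds shown alone.

Among the measured compounds shown here, in a functional assay on T47D cells (Homo sapiens) for cytotoxicity, read by MTT assay (a higher number here means a weaker inhibitor, a lower number a stronger inhibitor), compound 1 (`COc1ccc(C(=O)/C=C/c2ccc(F)cc2)c(O)c1`) gives 21900 nM as the only number available. Compound 2 (`COc1ccc(/C=C/C(=O)c2ccc(O)cc2)cc1Br`) carries "not determined" (no result reported) and so offers no comparison. Compound 3 (`O=C(/C=C/c1ccc(F)cc1)c1ccc(O)cc1O`) differs from compound 1 by hydrogen in place of methyl on an oxygen on an aromatic ring and has hydrogen in place of methyl on an oxygen on an aromatic ring, a change from methoxy to hydroxy. For the measured compounds named here, no measured step in this assay shows what this change does, so no shift beyond the usual scatter is expected, in either direction. The expected step is a 1.1-fold lower number from compound 1 to compound 3 (0.04 log units; within the scatter) and no more. Compound 3 is expected at 20000 nM (estimated range 8000 nM to 50000 nM).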

Compound 3, half-maximal inhibitory concentration: 8310 nM
Estimate against measurement, compound 3: 2.4-fold (0.38 log units) above, and the stated range covers the measured number.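

Among the compounds shown here, this is the first measured step at this oxygen on an aromatic ring. In this assay, putting hydrogen in place of methyl, methoxy to hydroxy, gives a 2.6-fold lower number from compound 1 to compound 3 (0.42 log units; beyond the scatter) and so a modestly stronger inhibitor, which shows that the read-out responds to this small change at this place. Nothing measured here accounts for the shift.

One pair cannot show whether the same change would hold on another core. As far as these compounds go, an ethoxy group, a longer chain on the same oxygen, or an amine in place of the hydroxy remains open.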